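From a Dichlorophenylamino Group to a Plain Phenyl

A few compounds are considered here, and "the series" means these few. Any claim that something is new, unique, unknown or untested is made for them only; others in the source may bear on it.

Three close relatives share one core and differ only in the halogens on an outer ring. In a functional assay on Raji cells (Homo sapiens) for cytotoxicity, with a stated time of 72 h (on this read-out higher numbers stand for an effect only at larger amounts of compound and lower numbers for an effect already at smaller amounts), compound 1 `C=C[C@@](C)(/C=C/c1ccc(Nc2ccc(F)c(F)c2)cc1)CCC=C(C)C` gives > 26000 nM as a limit of the assay and not a number. Compound 2 `C=C[C@@](C)(/C=C/c1ccc(Nc2ccc(Cl)c(F)c2)cc1)CCC=C(C)C` gives > 26000 nM as a limit too. Compound 3 `C=C[C@@](C)(/C=C/c1ccc(Nc2ccc(Cl)c(Cl)c2)cc1)CCC=C(C)C` gives > 26000 nM as a limit as well. All three therefore stand together at the limit of > 26000 nM in this assay, at which 3 of the 3 values shown sit, and none can be ranked against the others.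

Compound 4 `C=C[C@@](C)(/C=C/c1ccc(-c2ccccc2)cc1)CCC=C(C)C` carries a different kind of change: phenyl in place of (3,4-dichlorophenyl)amino on an aromatic carbon, para to a large group, as counted in phenyl in place of (3,4-dichlorophenyl)amino on an aromatic carbon here.

The measured steps are only chloro in place of fluoro or a swap of the whole dihalophenyl group. They are a step that the two limits leave unreadable from compound 1 to compound 2 and a step that the two limits leave unreadable from compound 2 to compound 3 and a step that the two limits leave unreadable from compound 1 to compound 3 with no size to carry over. None of them removes the nitrogen, so they are weak guides for this change. No step beyond the usual scatter is therefore expected, and no direction can be given.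

The estimate means a number no higher from compound 3 to compound 4 (the limit leaves the size open) as the expected step. For compound 4 the estimated value is 26000 nM with an expected range from 10000 nM to 60000 nM and quite possibly only a limit again.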

Compound 4, half-maximal effective concentration: > 26000 nM
Compound 4: a limit, no number; the forecaster's own chance of this, stated with the estimate: 75%; the middle value sits exactly at the limit.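

In this assay compound 4 gives > 26000 nM, again a limit and not a number. Among the compounds shown here, no step from compound 1, compound 2 or compound 3 to compound 4 can be read, since all four share one ceiling: the limit of > 26000 nM in this assay, at which 4 of the 4 values shown sit. The compounds shown leave open whether any of the four has an effect at larger amounts, and how far apart they would then lie.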